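The source may report more compounds than this note shows. Statements on the series, on what has been measured and on what is new or still open speak of the compounds shown alone.

Working notes on the series. In a functional assay on MCF7 cells (Homo sapiens) for cytotoxicity, read by MTT assay (a lower number here means a stronger inhibitor, a higher number a weaker inhibitor), compound 1 `CC(C)[C@H](NC(=S)Nc1ccccc1)c1nc2ccccc2[nH]1` gives 9800 nM, compound 2 `CC(C)C[C@H](NC(=S)Nc1ccccc1)c1nc2ccccc2[nH]1` gives 25800 nM, and compound 3 `C[C@@H](NC(=S)Nc1ccccc1)c1nc2ccccc2[nH]1` gives 16400 nM. Compound 3 stands second highest of the three numbers; its gaps to compound 2 and to compound 1 both lie within the scatter, so no order among these three is claimed. For the measured compounds named here, the one step in the set, a 2.6-fold higher number from compound 1 to compound 2 (0.42 log units; beyond the scatter), concerns the chain and not the configuration.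

Compound 4 `C[C@H](NC(=S)Nc1ccccc1)c1nc2ccccc2[nH]1` differs from compound 3 only as follows: the two compounds have the same atoms and bonds and differ only in configuration as drawn: 1 of 1 stereo elements differ; a stereocentre at a saturated chain carbon is drawn R in compound 3 and S in compound 4. Going by the values given here, no measured step bears on this inversion, so its size and direction in this assay cannot be drawn from the series. The expected step of a 1.0-fold lower number from compound 3 to compound 4 (0.01 log units; within the scatter) is therefore centred on no change, with a wide range. Compound 4 is estimated at 16000 nM, with a range of 5500 nM to 48000 nM.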

Compound 4, half-maximal inhibitory concentration: 196000 nM
Beside the measured number, compound 4's estimate is 12-fold (1.09 log units) below it, and the stated range ends below it.
By their numbers in this assay, from the lowest: compounds 1, 3 and 2 (each within the scatter of the next, the first and the last beyond it); then compound 4.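

In this assay the configuration at this saturated chain carbon has a large effect, with a 12-fold higher number from compound 3 to compound 4 (1.08 log units; beyond the scatter) arising from the inversion alone, because of this: the fact that compounds 3 and 4 differ only in the configuration as drawn. The earlier compounds shown here showed only a change of chain, while compound 4 also stands clear of the others, with a 7.6-fold higher number from compound 2 to compound 4 (0.88 log units; beyond the scatter) and a 20-fold higher number from compound 1 to compound 4 (1.30 log units; beyond the scatter). Compound 4 is thus the weakest of the four, beyond the scatter to each.

From the compounds shown here alone, only compounds 3 and 4 form a pair of this kind, so whether the inversion has a similar effect with isopropyl or isobutyl on this carbon stays open. Going by these compounds, how a longer chain or an amine at this carbon would behave in either configuration also stays open.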